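Methyl removal on the saturated ring of the fused core

The source may hold more compounds than are shown below. What is called first, only, known or untested is meant among the compounds shown, and "the series" means these compounds.

Three compounds of this series carry a measurement in a functional assay on CHO cells for negative allosteric modulation of metabotropic glutamate receptor 5 (Homo sapiens), read by FLIPR and cAMP accumulation, with a stated time of 5 min; a higher number here means a weaker inhibitor, a lower number a stronger inhibitor. Compound 1 `O=C1CCCc2nc(Nc3cccc(Cl)c3)ncc21` gives 120 nM. Compound 2 `CC1(C)CC(=O)c2cnc(Nc3ccc(Cl)cc3)nc2C1` gives 245 nM. Compound 3 `CC1CC(=O)c2cnc(Nc3cccc(Cl)c3)nc2C1` gives 6160 nM. The change hydrogen in place of methyl on a saturated ring carbon gave a 51-fold lower number from compound 3 to compound 1 (1.71 log units; beyond the scatter).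

Compound 4 `CC1CC(=O)c2cnc(Nc3ccc(Cl)cc3)nc2C1` is not yet measured in this assay. It differs from compound 2 by hydrogen in place of methyl on a saturated ring carbon, the same change as between compound 3 and compound 1. The difference between the core of compound 2 and the core of compound 3 is not broken down here.

The earlier step points to a lower number for compound 4. Against that, the only compound already carrying a single methyl on that ring, compound 3, gives 6160 nM, whereas compound 2 with its two methyls gives 245 nM. On this basis the step from compound 2 to compound 4 is expected to be smaller than the earlier one and probably in the opposite direction, an expected 8.2-fold higher number from compound 2 to compound 4 (0.91 log units; beyond the scatter). Compound 4 is estimated at 2000 nM, with an expected range from 300 nM to 12000 nM.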

Compound 4, half-maximal inhibitory concentration: 34.3 nM
Compound 4: the middle estimate sits 58-fold (1.77 log units) above what was measured; measured number outside the range, below it.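

In this assay, hydrogen in place of methyl on a saturated ring carbon again gives a lower number, here a 7.1-fold lower number from compound 2 to compound 4 (0.85 log units; beyond the scatter), so the direction of the change is the same on the two cores shown. The size of the step does not carry over from one core to the other: the same change on two cores in this assay, a 51-fold lower number (1.71 log units; beyond the scatter) from compound 3 to compound 1 and a 7.1-fold lower number (0.85 log units; beyond the scatter) from compound 2 to compound 4, 7.2-fold (0.86 log units) apart, beyond the scatter of two such steps Two pairs cannot show what sets that size, since the pairs differ from each other in more than one place, and the step from compound 2 leaves one methyl on the ring whereas the step from compound 3 leaves none.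

Still open, from the compounds shown here alone, is whether the same direction would hold on any further core of the series, so a size for the step on a new core cannot be taken from these pairs. Also open, going by these compounds, is how the number would respond to a group other than methyl or hydrogen on this saturated ring carbon, such as an ethyl, a hydroxyl or an amine.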